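The source may hold more compounds than are shown below. What is called first, only, known or untested is meant among the compounds shown, and "the series" means these compounds.

Measured so far in an ADME assay on the whole organism (plasma) for pharmacokinetics, with Rattus norvegicus as the target, with a stated time of 6 h, at a dose of 10 mg/kg by the oral route; on this read-out higher numbers stand for higher exposure at the dose given and lower numbers for lower exposure:

compound 1 `CCNc1nc(C)c(-c2nc3ccccc3s2)c(N[C@@H]2C[C@H](CO)[C@@H](O)[C@H]2O)n1`, 2580 ng.h/mL
compound 2 `Cc1nc(NC(C)C)nc(N[C@@H]2C[C@H](CO)[C@@H](O)[C@H]2O)c1-c1nc2ccccc2s1`, 8420 ng.h/mL
compound 3 `Cc1nc(NCC(C)C)nc(N[C@@H]2C[C@H](CO)[C@@H](O)[C@H]2O)c1-c1nc2ccccc2s1`, 1020 ng.h/mL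

Compound 2 stands highest of the three on this read-out: the nearest is compound 1, and the step of a 3.3-fold higher number from compound 1 to compound 2 (0.51 log units; beyond the scatter) is beyond the scatter; the furthest is compound 3, and the step of an 8.3-fold lower number from compound 2 to compound 3 (0.92 log units; beyond the scatter) is also beyond the scatter.

Compound 4 `Cc1nc(Nc2ccccc2)nc(N[C@@H]2C[C@H](CO)[C@@H](O)[C@H]2O)c1-c1nc2ccccc2s1` is not yet measured. It differs from compound 2 by phenyl in place of isopropyl on a nitrogen on an aromatic ring.

Among the compounds with values here, two measured steps touch the same nitrogen. The step of a 3.3-fold higher number from compound 1 to compound 2 (0.51 log units; beyond the scatter) shows that adding one carbon on the chain, hydrogen to methyl, raised exposure. The step of an 8.3-fold lower number from compound 2 to compound 3 (0.92 log units; beyond the scatter) shows that adding one more carbon, isopropyl to isobutyl, lowered it by more, and the step of a 2.5-fold lower number from compound 1 to compound 3 (0.40 log units; beyond the scatter) runs the same way. Within the data shown here, none of the measured steps puts a ring on this nitrogen, so phenyl is outside the range of what has been tested, and the direction is read from the fall seen on growing past isopropyl. A lower number for compound 4 is therefore expected, with a wide range.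

The estimate for compound 4 is 2000 ng.h/mL, between 500 ng.h/mL and 8000 ng.h/mL, which would be expected as a step of a 4.2-fold lower number from compound 2 to compound 4 (0.62 log units; beyond the scatter).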

Compound 4, area under the concentration-time curve: 742 ng.h/mL
For compound 4 the middle estimate is 2.7-fold (0.43 log units) above the measured one, within the range that was stated.
By their numbers in this assay, from the lowest: compounds 4 and 3 (each within the scatter of the next); then compound 1; then compound 2.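

In this assay, the first ring on this nitrogen, phenyl in place of isopropyl, gives an 11-fold lower number from compound 2 to compound 4 (1.05 log units; beyond the scatter), and the anilino compound also stands apart from the ethylamino one, with a 3.5-fold lower number from compound 1 to compound 4 (0.54 log units; beyond the scatter). Against isobutyl, phenyl gives a 1.4-fold lower number from compound 3 to compound 4 (0.14 log units; within the scatter), so compound 3 and compound 4 cannot be told apart, and among the four groups seen on this nitrogen, the high exposure of compound 2 is not matched by either the chain or the ring that is larger than isopropyl. No independent data bear on why exposure changes with the group at this position.

Still open, from the compounds shown here alone, is whether a saturated ring on this nitrogen, such as cyclopropyl or cyclohexyl, would stay with isopropyl or fall with phenyl, and whether a ring carrying its own nitrogen, such as pyridyl, would differ from phenyl. The compounds shown also leave open how tert-butyl or a substituted phenyl, for example fluorophenyl, would compare on this read-out, so the limits of the isopropyl result remain undefined.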